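Compound 1 to compound 3: one aryl swap, one estimate

The compounds below may be only part of what the source reports. "The series", "measured", "known", "first", "only" and "open" are said of these compounds alone.

Going by the values given here, compound 1 `COc1cccc(-n2cc(COc3ccc4c(c3)CCC4)nn2)c1` is the only compound here with a reported number: in an ADME assay on HEK293 cells (Homo sapiens) for inhibition, read by MTT assay, with a stated time of 48 h, tested at 25 uM (on this read-out lower numbers stand for less inhibition and higher numbers for more inhibition at the one concentration tested (going by the name of the read-out)), compound 1 gives 25.8%. Compound 2 `O=C(Cn1cc(COc2ccc3c(c2)CCC3)nn1)Nc1ccccc1Cl` was also entered into this assay, where compound 2 gives "not determined" (no result reported), so no result was reported for it. Compound 3 `Brc1ccccc1-n1cc(COc2ccc3c(c2)CCC3)nn1` has yet to be measured. It differs from compound 1 by 2-bromophenyl in place of 3-methoxyphenyl on an aromatic nitrogen. Among the compounds with values here, with no comparable step measured between two known compounds, the expected step of a number 4.2 percentage points higher from compound 1 to compound 3 (within the scatter) is taken as none beyond the usual scatter. Compound 3 is therefore estimated at 30% in this assay, within a range from 10% to 50%.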

Compound 3, a percentage reported as inhibition, at one concentration (the size of the read-out at that concentration, not a potency): 16.5%
Estimate against measurement, compound 3: 13.5 percentage points above; the measured number falls inside the stated range.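

Going by these compounds alone, with 2-bromophenyl in place of 3-methoxyphenyl on an aromatic nitrogen, this assay gives the first measured step at this position: a number 9.3 percentage points lower from compound 1 to compound 3 (within the scatter). The two aryl groups are therefore not told apart by this read-out, although the entering group brings bromine and the leaving group's hydrogen-bond acceptor is gone. Nothing available bears on the reason for this result.

Still open, as far as these compounds go, is whether an amine or a carboxylic acid on this phenyl ring would give a step beyond the scatter. A longer chain on the same aromatic nitrogen also remains an open case.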